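Two Ring Centres Turned Over, Starting From a Limit

This account rests on a few compounds, and the source may have more. Where it says the series, first, only, none or still open, it means among the compounds named here.

Compound 1 `C=C1CCCC(C)(C)C1CC[C@]1(C)CC[C@@H]([C@@H](C)C(=O)O)OO1` was tested in a functional assay on DU-145 cells (Homo sapiens) for inhibition; a higher number here means a weaker inhibitor of growth, a lower number a stronger inhibitor of growth. In this assay compound 1 gives only a limit, > 10000 nM, not a number; compound 1 thus stands at the limit of > 10000 nM in this assay, at which 1 of the 2 values shown sits. Compound 2 `C=C1CCCC(C)(C)C1CC[C@]1(C)CC[C@H]([C@@H](C)C(=O)OC)OO1` in this assay gives 3670 nM. Compound 3 `C=C1CCCC(C)(C)C1CC[C@@]1(C)CC[C@H]([C@@H](C)C(=O)O)OO1` has not yet been measured. It differs from compound 1 as follows: the two compounds have the same atoms and bonds; at least one stereo element is drawn with a configuration in one of them and without one in the other: 2 of 4 stereo elements differ; a stereocentre at a saturated ring carbon is drawn R in compound 1 and S in compound 3; a stereocentre at a saturated ring carbon is drawn S in compound 1 and R in compound 3. Going by the values given here, no measured pair turns ring stereocentres in this way, so the size of such a step is unknown here. The step from compound 1 to compound 3 is expected to be a number no higher from compound 1 to compound 3 (the limit leaves the size open), either way. Compound 3 is estimated at 10000 nM, in a range from 3000 nM to 30000 nM.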

Compound 3, concentration for 50% growth inhibition: 2710 nM
Compound 3: the middle estimate sits 3.7-fold (0.57 log units) above what was measured; measured number below the stated range.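

In this assay, turning over the two ring stereocentres while keeping every atom and bond gives an at least 3.6-fold lower number from compound 1 to compound 3 (0.56 log units; beyond the scatter). The spatial arrangement at these two ring carbons alone is thus enough to shift growth inhibition, something compound 1 and compound 2 could not show. The size of this step has only a lower bound: the limit of > 10000 nM in this assay, at which 1 of the 3 values shown sits.

The compounds shown do not separate the two ring centres from each other. Nor do they tell how an amide in place of the carboxylic acid would behave with this ring arrangement.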